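From Benzyl Carbamate to Morpholine Urea on a Biaryl

The source may report more compounds than this note shows. Statements on the series, on what has been measured and on what is new or still open speak of the compounds shown alone.

Compound 1 `CCOC(=O)Nc1cccc(-c2ccc(N(C)C)cc2)c1` gives 3000 nM in an assay on COS-7 cells for inhibition of patatin-like phospholipase domain-containing protein 2 (Mus musculus); a lower number here means a stronger inhibitor, a higher number a weaker inhibitor. Compound 2 `CN(C)c1ccc(-c2cccc(NC(=O)OCc3ccccc3)c2)cc1` reaches only a limit of > 200000 nM in this assay, so its standing is bounded from one side alone. Among the measured compounds shown here, the single measured step, an at least 66-fold higher number from compound 1 to compound 2 (1.82 log units; beyond the scatter), is large, with compound 2 sitting at the limit of > 200000 nM in this assay, at which 1 of the 2 values shown sits. Compound 3 `CN(C)c1ccc(-c2cccc(NC(=O)N3CCOCC3)c2)cc1` differs from compound 2 by morpholin-4-yl in place of benzyloxy on a carbonyl carbon; the benzyloxy that accompanied that large step leaves. Compound 3 is therefore expected to move back toward compound 1, a step of an at least 10-fold lower number from compound 2 to compound 3 (1.00 log units; beyond the scatter). The estimate for compound 3 in this assay is 20000 nM, within 2000 nM to 200000 nM.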

Compound 3, half-maximal inhibitory concentration: > 200000 nM
Compound 3 was reported as a limit; the forecaster's own chance of this, stated with the estimate: 30%; middle value at least 10-fold (1.00 log units) away from the limit.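

Replacing ethoxy with morpholin-4-yl on the carbonyl carbon gives an at least 66-fold higher number from compound 1 to compound 3 (1.82 log units; beyond the scatter), so the loss seen with benzyloxy is not confined to that one group. Compound 3, like compound 2, is reported only as a limit, and the step between them cannot be read. Of the three groups shown on this carbonyl carbon, only ethoxy gives a number, while the other two end at a limit: the limit of > 200000 nM in this assay, at which 2 of the 3 values shown sit.

On these data alone, whether methoxy or a dimethylamino group at this place would restore a number like that of compound 1 stays open. So does how compound 2 and compound 3 rank against each other.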